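Adding a Fluoro to Compound 2

This account rests on a few compounds, and the source may have more. Where it says the series, first, only, none or still open, it means among the compounds named here.

Measured in a functional assay, with a stated time of 10 min; a lower number here means a stronger inhibitor, a higher number a weaker inhibitor:
- Compound 1 `O=c1cc(/C=C/c2cccc(F)c2)[nH]cc1O`: 6290 nM
- Compound 2 `Cn1cc(O)c(=O)cc1/C=C/c1ccccc1`: 2110 nM

Of these two, compound 2 has the lower number, 2110 nM, which makes it the stronger inhibitor, and its gap to compound 1 lies beyond the usual scatter. Compound 3 `Cn1cc(O)c(=O)cc1/C=C/c1cccc(F)c1` is compound 2 with a single change: fluoro in place of hydrogen on an aromatic carbon. This is fluoro in place of hydrogen on an aromatic carbon, meta to a large group. Compound 1 also carries this fluoro, but it differs from compound 2 in a second place as well, so the two measured values cannot isolate the change. With no direct measurement of this change, no shift beyond the scatter is expected in this assay. The estimated size of a 1.2-fold lower number from compound 2 to compound 3 (0.07 log units; within the scatter) is therefore small. Compound 3 is expected to give 1800 nM, with an estimated range of 700 nM to 4500 nM.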

Compound 3, half-maximal inhibitory concentration: 1310 nM
For compound 3 the middle estimate is 1.4-fold (0.14 log units) above the measured one, and the stated range covers the measured number.
By their numbers in this assay, from the lowest: compounds 3 and 2 (each within the scatter of the next); then compound 1.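

In this assay, fluoro in place of hydrogen on an aromatic carbon, meta to a large group, gives a 1.6-fold lower number from compound 2 to compound 3 (0.21 log units; within the scatter), so this change alone moves the number no further than repeat measurements would, a point that compounds 1 and 2 could not settle because they differ in two places. Compounds 1 and 3 share the fluoro and differ only in methyl in place of hydrogen on an aromatic nitrogen, and this change gives a 4.8-fold lower number from compound 1 to compound 3 (0.68 log units; beyond the scatter), a modest step but one that clearly exceeds the scatter. Nothing measured here explains why either step has its size.

Still open, as far as these compounds go, is whether a larger group at the fluoro's place, such as chloro or methoxy, would shift the number further. Also open, from the compounds shown here alone, is whether a longer chain, such as ethyl, could replace the methyl on the nitrogen.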